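Cytotoxicity notes: a longer chain on the amide-type nitrogen

The source may report more compounds than this note shows. Statements on the series, on what has been measured and on what is new or still open speak of the compounds shown alone.

Compound 1 `FC(F)(F)c1cccc(NC(=S)Nc2cccc(Br)c2)c1` gives 9200 nM in an ADME assay on MT4 cells (Homo sapiens) for cytotoxicity; on this read-out lower numbers stand for higher toxicity in this test and higher numbers for lower toxicity in this test. Compound 2 `COc1cccc(NC(=S)Nc2cccc(C(F)(F)F)c2)c1` gives 26000 nM in this assay, and the step of a 2.8-fold higher number from compound 1 to compound 2 (0.45 log units; beyond the scatter) is modest. Compound 3 `CCNC(=S)Nc1cccc(C(F)(F)F)c1` shows only a limit of the assay, > 100000 nM in this assay. The step of an at least 10-fold higher number from compound 1 to compound 3 (1.03 log units; beyond the scatter) is large, and compound 3 stands at the limit of > 100000 nM in this assay, at which 1 of the 3 values shown sits, the highest point any value here reaches.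

Compound 4 `C=C(C)CNC(=S)Nc1cccc(C(F)(F)F)c1` carries 1-methylethenyl in place of methyl on a saturated chain carbon bound to an amide-type nitrogen. Within the data shown here, only the step of an at least 10-fold higher number from compound 1 to compound 3 (1.03 log units; beyond the scatter) touches this nitrogen, and it ran up to the limit; a small chain is retained here, so no step beyond the scatter is expected in this assay. Compound 4 is expected at 100000 nM, with a range of 50000 nM to 200000 nM, most likely again as a limit. The expected step is a number no higher from compound 3 to compound 4 (the limit leaves the size open).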

Compound 4, half-maximal cytotoxic concentration: 43000 nM
The estimate for compound 4 lay 2.3-fold (0.37 log units) above the measured number; the measured number lies below the stated range.
By their numbers in this assay, from the lowest: compound 1; then compounds 2 and 4 (each within the scatter of the next). At a limit, above all of these: compound 3.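

On this saturated chain carbon bound to an amide-type nitrogen, 1-methylethenyl in place of methyl brings the small-chain thiourea from a limit to a number in this assay (an at least 2.3-fold lower number from compound 3 to compound 4 (0.36 log units; beyond the scatter)), so a small chain alone does not keep the value at the limit. The value of compound 3 is a limit: (the limit of > 100000 nM in this assay, at which 1 of the 4 values shown sits). The 2-methylprop-2-en-1-yl chain still reads beyond the scatter against 3-bromophenyl (a 4.7-fold higher number from compound 1 to compound 4 (0.67 log units; beyond the scatter)).

From the compounds shown here alone, whether the added carbons or the double bond carry the change stays open. A saturated 2-methylpropyl chain would separate the two.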